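Trimethoxyphenyl Replaces Methoxyphenyl on the Shared Core

This account rests on a few compounds, and the source may have more. Where it says the series, first, only, none or still open, it means among the compounds named here.

Three compounds share one core and differ only in the aryl group on the five-membered ring. In a functional assay on HCT-116 cells (Homo sapiens) for inhibition (on this read-out higher numbers stand for weaker inhibition of growth and lower numbers for stronger inhibition of growth), compound 1 `COc1cc(/C=C/C(=O)c2cccc(-n3cc(-c4ccc(Cl)cc4)[nH]c3=O)c2)cc(OC)c1OC` gives 1390 nM, compound 2 `COc1cc(/C=C/C(=O)c2cccc(-n3cc(-c4ccccc4)[nH]c3=O)c2)cc(OC)c1OC` gives 330 nM, and compound 3 `COc1ccc(-c2cn(-c3cccc(C(=O)/C=C/c4cc(OC)c(OC)c(OC)c4)c3)c(=O)[nH]2)cc1` gives 370 nM. Compound 3 thus holds the second highest of the three numbers: a 1.1-fold higher number from compound 2 to compound 3 (0.05 log units; within the scatter) places it within the scatter of compound 2, while a 3.8-fold lower number from compound 1 to compound 3 (0.57 log units; beyond the scatter) sets it clearly apart from compound 1. Compound 4 `COc1cc(/C=C/C(=O)c2cccc(-n3cc(-c4cc(OC)c(OC)c(OC)c4)[nH]c3=O)c2)cc(OC)c1OC` carries 3,4,5-trimethoxyphenyl in place of 4-methoxyphenyl on an aromatic carbon. The two steps that bear on this change show that a single methoxy on this ring shifts the number little against hydrogen, so compound 4 is expected to stay close to compound 3, with a 1.1-fold higher number from compound 3 to compound 4 (0.06 log units; within the scatter) inside the scatter. Compound 4 is therefore estimated at 420 nM, in a range from 150 nM to 1200 nM.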

Compound 4, concentration for 50% growth inhibition: 740 nM
The estimate for compound 4 lay 1.8-fold (0.25 log units) below the measured number, within the range that was stated.
By their numbers in this assay, from the lowest: compounds 2, 3, 4 and 1 (each within the scatter of the next, the first and the last beyond it).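

In this assay, with a 2.0-fold higher number from compound 3 to compound 4 (0.30 log units; within the scatter) the 3,4,5-trimethoxyphenyl group cannot be told apart from 4-methoxyphenyl at this position. Yet a 2.2-fold higher number from compound 2 to compound 4 (0.35 log units; beyond the scatter) shows that, unlike 4-methoxyphenyl, it separates from phenyl, though only modestly, while a 1.9-fold lower number from compound 1 to compound 4 (0.27 log units; within the scatter) leaves it unresolved from 4-chlorophenyl, a group that 4-methoxyphenyl did clear. Nothing at hand explains these steps. The compounds shown leave open how this position would respond to an aryl ring carrying an amine or a carboxylic acid, or to a longer chain in place of the aryl ring.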